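Diastereomer of a weakly cytotoxic tetrahydropyran against HeLa cells

The source may report more compounds than this note shows. Statements on the series, on what has been measured and on what is new or still open speak of the compounds shown alone.

Measured so far:
compound 1, `COc1ccc(/C=C/C[C@H]2C[C@H]([C@H](O)c3ccc(OC)c(OC)c3)CO[C@@H]2c2ccc(OC)c(OC)c2)cc1OC`, 34600 nM
compound 2, `O[C@@H](c1ccccc1)[C@H]1CO[C@H](c2ccccc2)[C@@H](C/C=C/C2CCCC2)C1`, 9330 nM

The account begins with compound 1, whose structure is `COc1ccc(/C=C/C[C@H]2C[C@H]([C@H](O)c3ccc(OC)c(OC)c3)CO[C@@H]2c2ccc(OC)c(OC)c2)cc1OC`. For the measured compounds named here, in a functional assay on HeLa cells (Homo sapiens) for cytotoxicity, read by WST assay, with a stated time of 48 h (a higher number here means a weaker inhibitor, a lower number a stronger inhibitor), compound 1 gives 34600 nM, the highest of the two numbers known here. Compound 2, `O[C@@H](c1ccccc1)[C@H]1CO[C@H](c2ccccc2)[C@@H](C/C=C/C2CCCC2)C1`, gives 9330 nM in this assay, a lower number, and the gap between the two lies beyond the scatter of repeated measurements. Compound 3, `COc1ccc(/C=C/C[C@H]2C[C@@H]([C@@H](O)c3ccc(OC)c(OC)c3)CO[C@@H]2c2ccc(OC)c(OC)c2)cc1OC`, has not yet been measured. It differs from compound 1 only in configuration: the two compounds have the same atoms and bonds and differ only in configuration as drawn: 2 of 5 stereo elements differ; a stereocentre at a saturated ring carbon is drawn S in compound 1 and R in compound 3; a stereocentre at a saturated chain carbon is drawn S in compound 1 and R in compound 3. Going by the values given here, no measured pair here shows what such a change in configuration does, so the direction is open. Because compound 1 gives 34600 nM, the step from compound 1 to compound 3 is expected to be modest, a 1.4-fold lower number from compound 1 to compound 3 (0.14 log units; within the scatter), not clearly beyond the scatter. Compound 3 is therefore estimated at 25000 nM, within a range from 8000 nM to 80000 nM.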

Compound 3, half-maximal inhibitory concentration: 23800 nM
The estimate for compound 3 lay 1.1-fold (0.02 log units) above the measured number; low and high end bracket the measured number.
By their numbers in this assay, from the lowest: compound 2; then compounds 3 and 1 (each within the scatter of the next).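

For the compounds shown here, this pair gives the first reading of what a change in configuration does: the fact that compounds 1 and 3 differ only in the configuration as drawn. In this assay, redrawing both the stereocentre at the saturated ring carbon and the one at the saturated chain carbon from S to R gives a 1.5-fold lower number from compound 1 to compound 3 (0.16 log units; within the scatter), so the assay does not separate the two diastereomers. At these two stereocentres taken together, then, the change leaves the cytotoxicity reading indistinguishable from that of the parent arrangement, and both compounds remain weakly cytotoxic in this assay.

The compounds shown leave open what a change at only one of the two stereocentres would do, since both change together in this pair. They also leave open whether an amine or a carboxylic acid in place of the hydroxyl group would shift the number in either configuration.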